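The source may hold more compounds than are shown below. What is called first, only, known or untested is meant among the compounds shown, and "the series" means these compounds.

Compound 1 `N#CC1=C(NC(=O)C2CC2)N(c2ccc(S(N)(=O)=O)cc2)C2=C(C(=O)CCC2)C1c1ccc(Cl)cc1Cl` carries a cyclopropyl on the carbonyl carbon of the amide, and in a functional assay on Ehrlich cells (Mus musculus) for cytotoxicity, read by trypan blue exclusion, with a stated time of 2 h, tested at 10 ug/mL (on this read-out higher numbers stand for a stronger effect at the one concentration tested and lower numbers for a weaker effect), compound 1 gives 20%. Going by the values given here, compound 2 `N#CC1=C(NC(=O)c2ccc([N+](=O)[O-])cc2)N(c2ccc(S(N)(=O)=O)cc2)C2=C(C(=O)CCC2)C1c1ccc(Cl)cc1Cl` has 4-nitrophenyl in that place; in this assay compound 2 gives 40%, the higher of the two numbers measured so far, and the step of a number 20 percentage points higher from compound 1 to compound 2 (beyond the scatter) is the only one known. Compound 3 `COc1cc(C(=O)NC2=C(C#N)C(c3ccc(Cl)cc3Cl)C3=C(CCCC3=O)N2c2ccc(S(N)(=O)=O)cc2)cc(OC)c1OC` is not yet measured. It differs from compound 2 in one place: 3,4,5-trimethoxyphenyl in place of 4-nitrophenyl on a carbonyl carbon. Among the compounds with values here, the one measured step also altered the group on the carbonyl carbon, but there a cyclopropyl was replaced by an aromatic ring, whereas here one aromatic ring stands in for another; the step of a number 20 percentage points higher from compound 1 to compound 2 (beyond the scatter) therefore bears on the change only loosely, and no measured pair shows what exchanging one substituted phenyl for another does in this assay. With nothing pointing in either direction, the step expected for compound 3 in this assay is a number 2 percentage points lower from compound 2 to compound 3 (within the scatter), none beyond the scatter. For compound 3 the estimate in this assay is 38%, with a range from 20% to 56%.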

Compound 3, a percentage reported as activity, at one concentration (the size of the read-out at that concentration, not a potency): 0%
Compound 3: middle estimate off by 38 percentage points, on the high side; measured number below the stated range.
By their numbers in this assay, from the lowest: compound 3; then compound 1; then compound 2.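

Exchanging one substituted phenyl for another on the carbonyl carbon whose other neighbour is the amide-type nitrogen has a large effect in this assay, with a number 40 percentage points lower from compound 2 to compound 3 (beyond the scatter), so this position responds to the identity of the aromatic group and not just to its presence. An aromatic ring here does not by itself raise the number: with a number 20 percentage points lower from compound 1 to compound 3 (beyond the scatter), the 3,4,5-trimethoxyphenyl amide falls on the opposite side of the cyclopropyl amide from the 4-nitrophenyl amide, and the cyclopropyl amide lies between the two. Nothing available links this drop to any property of either group.

From the compounds shown here alone, the two phenyl groups differ in both their substituents and the number of those substituents, so it remains open whether the nitro group, the methoxy groups or their number tracks the change; an unsubstituted phenyl or a phenyl carrying a single methoxy group would help separate these. Also open, going by these compounds, is how an amine, a carboxylic acid or a longer alkyl chain on the carbonyl carbon would read at this single concentration.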